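Working notes: compound 2 to compound 4 in the cell assay

The source may hold more compounds than are shown below. What is called first, only, known or untested is meant among the compounds shown, and "the series" means these compounds.

Compound 1 `COc1cc(OC)c(OC)cc1/C=C/C(=O)c1ccc(OC)c2c1OC(C)(C)C=C2`, compound 2 `COc1ccc(C(=O)/C=C/c2ccc(Br)cc2)c2c1C=CC(C)(C)O2` and compound 3 `COc1ccc(C(=O)/C=C/c2ccc(N(c3ccccc3)c3ccccc3)cc2)c2c1C=CC(C)(C)O2` share one core and differ only in the ring carried on the chain. In a functional assay on SW-620 cells (Homo sapiens) for antiproliferative activity, read by MTT assay, with a stated time of 24 h (a lower number here means a stronger inhibitor, a higher number a weaker inhibitor), compound 1 gives > 10000 nM, a limit of the assay rather than a number. Compound 2 likewise gives > 10000 nM, again a limit. Compound 3 gives > 10000 nM, also a limit. Compound 2 therefore stands at the limit of > 10000 nM in this assay, at which 3 of the 3 values shown sit; no measured number separates any of the three. Compound 4 `COc1ccccc1/C=C/C(=O)c1ccc(OC)c2c1OC(C)(C)C=C2` is not yet measured and differs from compound 2 by 2-methoxyphenyl in place of 4-bromophenyl on a double-bonded chain carbon bound to a double-bonded chain carbon. Going by the values given here, no measured step exists to judge this change, so no shift in this assay beyond the scatter is expected in either direction. Compound 4 is expected to give 15000 nM in this assay, between 7000 nM and 40000 nM, the step that the limit leaves unreadable from compound 2 to compound 4 being estimated as essentially none, most likely reported again as a limit.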

Compound 4, half-maximal inhibitory concentration: > 10000 nM
Compound 4 gave a limit, no number (the forecaster's own chance of this, stated with the estimate: 85%); the middle value does not contradict the limit.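

No step can be read from compound 2 to compound 4, since both stay at a limit in this assay: the limit of > 10000 nM in this assay, at which 4 of the 4 values shown sit.

The compounds shown leave open whether any ring carried on the chain of the shared core gives a measurable value in this assay.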